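Notes on the step from compound 2 to compound 4

The source may report more compounds than this note shows. Statements on the series, on what has been measured and on what is new or still open speak of the compounds shown alone.

- compound 1 `COc1ccccc1N1C(=O)CSC1c1cc(F)cc(C(=O)NCCCCc2ccccc2)c1`: 10000 nM
- compound 2 `COc1ccc(F)cc1N1C(=O)CSC1c1cccc(C(=O)NCCCCc2ccccc2)c1`: 10000 nM
- compound 3 `Cc1ccnc(N2C(=O)CSC2c2cccc(C(=O)NCCCCn3cccn3)c2)c1`: 50000 nM

In a physicochemical assay for solubility, read by turbidimetry, measured as kinetic solubility, at pH 7.4 (on this read-out lower numbers stand for lower solubility and higher numbers for higher solubility), compound 2 stands level with compound 1 at 10000 nM. These two are the lowest of the three, and compound 3 is higher at 50000 nM.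

Compound 4 `O=C(NCCCCc1ccccc1)c1cccc(C2SCC(=O)N2c2cccc(F)c2)c1` differs from compound 2 by hydrogen in place of methoxy on an aromatic carbon, ortho to a large group and para to a fluoro group. Among the measured compounds shown here, no measured pair isolates this change, so no step beyond the scatter is expected in this assay, in either direction. The estimated change is a 1.2-fold higher number from compound 2 to compound 4 (0.08 log units; within the scatter), expected to stay within the scatter. For compound 4 the expected value is 12000 nM, with an estimated range of 5000 nM to 30000 nM.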

Compound 4, solubility: 10000 nM
The estimate for compound 4 lay 1.2-fold (0.08 log units) above the measured number, within the range that was stated.
By their numbers in this assay, from the lowest: compounds 1, 2 and 4 (each within the scatter of the next); then compound 3.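

In this assay, hydrogen in place of methoxy on this aromatic carbon, ortho to a large group and para to a fluoro group, gives no change at the digits printed from compound 2 to compound 4 (within the scatter) as 5-fluoro-2-methoxyphenyl becomes 3-fluorophenyl. Among the compounds shown, this is the only pair that differs in one place, and it shows that the methoxy can be lost here without a step beyond the scatter. Nothing available accounts for this result.

Going by these compounds, whether an amine or a carboxylic acid on this carbon would also leave the number level remains open. Compound 3 differs from the others in more than one place, so its 50000 nM cannot be tied to any single change.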